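Swapping in tert-butyl where every reading sits at a limit

The compounds below may be only part of what the source reports. "The series", "measured", "known", "first", "only" and "open" are said of these compounds alone.

In a functional assay on KYSE-70 cells for antiproliferative activity against KYSE-70 cell line (Homo sapiens), read by MTT assay, with a stated time of 72 h (a higher number here means a weaker inhibitor, a lower number a stronger inhibitor), compound 1 (`COc1ccc(NC(=O)c2cc(=O)[nH]c3cc(Br)ccc23)cc1`) gives > 20000 nM as a limit of the assay, not a number. Compound 2 (`O=C(Nc1ccc(Cl)cc1)c1cc(=O)[nH]c2cc(Br)ccc12`) likewise gives only the limit > 20000 nM with no number behind it. Compound 3 (`O=C(Nc1ccc(OC(F)(F)F)cc1)c1cc(=O)[nH]c2cc(Br)ccc12`), the starting point here, also gives only the limit > 20000 nM and so has no exact place on the scale.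

The next structure is compound 4 (`CC(C)(C)c1ccc(NC(=O)c2cc(=O)[nH]c3cc(Br)ccc23)cc1`), which carries tert-butyl in place of trifluoromethoxy on an aromatic carbon. Three measured changes of the group at this same place bear on it. One is a step that the two limits leave unreadable from compound 1 to compound 2 and another is a step that the two limits leave unreadable from compound 1 to compound 3 while the third is a step that the two limits leave unreadable from compound 2 to compound 3 as well. None of them has a readable size, so they point in no direction.

The expectation for compound 4 therefore leans on compound 3 and its limit of > 20000 nM together with the limit of > 20000 nM in this assay, at which 3 of the 3 values shown sit, in this series. A clear gain in this assay is not expected, and another limit is the likeliest report. The expected change is a step that the limit leaves unreadable from compound 3 to compound 4 and remains only an estimate. For compound 4 the estimated value is 25000 nM with an expected range from 10000 nM to 50000 nM if a number is reported at all.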

Compound 4, half-maximal inhibitory concentration: > 20000 nM
Compound 4 was reported as a limit (the forecaster's own chance of this, stated with the estimate: 75%); the middle value is on the limit's open side.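

In this assay compound 4 gives > 20000 nM, which is a limit and not a number. No step from compound 1, compound 2 or compound 3 to compound 4 can be read, and the limit is shared across the series: the limit of > 20000 nM in this assay, at which 4 of the 4 values shown sit.

The compounds shown leave open how these four groups rank, and whether any group at this place gives a measurable value in this assay.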